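The source may hold more compounds than are shown below. What is called first, only, known or untested is meant among the compounds shown, and "the series" means these compounds.

Measured compounds:
Compound 1, `CC(C)=CCOc1cc(=O)n(CCCO)c2c1CC(CC=C(C)C)C(C)(C)C2`, gives 7.5%.
Compound 2, `CC(C)=CCC1Cc2c(OCCCNS(=O)(=O)c3ccc(Cl)cc3)cc(=O)n(CCCO)c2CC1(C)C`, gives 9.8%.
Compound 3, `CC(C)=CCC1Cc2c(OCCCNS(=O)(=O)c3ccc([N+](=O)[O-])cc3)cc(=O)n(CCCO)c2CC1(C)C`, gives 17.3%.

These numbers come from a functional assay on PANC-1 cells (Homo sapiens) for inhibition, read by MTT assay, with a stated time of 24 h, tested at 10 uM; a lower number here means less inhibition, a higher number more inhibition at the concentration tested (going by the name of the read-out). Compound 1 has the lowest of the three, yet its gaps to compound 2 and to compound 3 both lie within the scatter, so the three cannot be told apart on these numbers. Among the compounds with values here, the single step between compounds that differ in one place, a number 7.5 percentage points higher from compound 2 to compound 3 (within the scatter), is within the scatter as well. Compound 4, `COc1ccccc1NC(=O)Oc1cc(=O)n(CCCO)c2c1CC(CC=C(C)C)C(C)(C)C2`, differs from compound 1 by (2-methoxyphenyl)carbamoyl in place of 3-methylbut-2-en-1-yl on an oxygen on an aromatic ring. Within the data shown here, no measured step touches this oxygen or brings in a carbamoyl group, so there is no basis for a direction; the only guide is that every change seen so far stayed within the scatter. For compound 4 a step of a number 4.5 percentage points higher from compound 1 to compound 4 (within the scatter) is therefore expected, nothing beyond the scatter. Compound 4 is estimated at 12%, within 0% to 30%.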

Compound 4, a percentage reported as inhibition, at one concentration (the size of the read-out at that concentration, not a potency): 0%
Compound 4: the middle estimate sits 12 percentage points above what was measured; low and high end bracket the measured number.
By their numbers in this assay, from the lowest: compounds 4, 1, 2 and 3 (each within the scatter of the next, the first and the last beyond it).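

Swapping 3-methylbut-2-en-1-yl for (2-methoxyphenyl)carbamoyl on this oxygen brings an aromatic ring and a carbamoyl group to a place no earlier step had touched, and in this assay the change gives a number 7.5 percentage points lower from compound 1 to compound 4 (within the scatter). Even this exchange of one quite different group for another therefore does not separate the two compounds. No measurement shown here offers an explanation for this result.

Going by these compounds, whether a carboxylic acid or a simple amine on this oxygen would give a step beyond the scatter remains open. So does the question of whether a plain phenylcarbamoyl group, without the methoxy, would behave the same way.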